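Swapping the trifluoromethyl phenyl ether for a difluorophenyl ether

This account rests on a few compounds, and the source may have more. Where it says the series, first, only, none or still open, it means among the compounds named here.

Compound 1 `CC(C)[C@H](NC(=O)COc1cccc2ccccc12)C(=O)N[C@@H](CC(=O)O)C(=O)COc1cccc(C(F)(F)F)c1` stands at the limit of a functional assay on Jurkat cells (Homo sapiens) (a higher number here means a weaker inhibitor, a lower number a stronger inhibitor), where compound 1 gives > 100000 nM. Its two measured neighbours share that position. Compound 2 `CC(=O)Nc1cccc(OCC(=O)[C@H](CC(=O)O)NC(=O)[C@@H](NC(=O)COc2cccc3ccccc23)C(C)C)c1` gives > 100000 nM, a limit of the assay. Compound 3 `CC(C)[C@H](NC(=O)COc1cccc2ccccc12)C(=O)N[C@@H](CC(=O)O)C(=O)COc1ccccc1F` gives > 100000 nM, likewise a limit. The steps among them, a step that the two limits leave unreadable from compound 1 to compound 2, a step that the two limits leave unreadable from compound 1 to compound 3 and a step that the two limits leave unreadable from compound 2 to compound 3, cannot be sized; all three values show only (the limit of > 100000 nM in this assay, at which 3 of the 3 values shown sit). Compound 4 `CC(C)[C@H](NC(=O)COc1cccc2ccccc12)C(=O)N[C@@H](CC(=O)O)C(=O)COc1cc(F)cc(F)c1` differs from compound 1 by 3,5-difluorophenyl in place of 3-(trifluoromethyl)phenyl on an oxygen on a saturated carbon. No measured step reads how this assay answers an exchange at that oxygen on a saturated carbon, since every shown change there left the read-out at the limit. One expects compound 4 to remain at the limit too, so the step that the limit leaves unreadable from compound 1 to compound 4 is estimated as unreadable. Compound 4 is accordingly estimated at 150000 nM, within 50000 nM to 500000 nM.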

Compound 4, half-maximal inhibitory concentration: > 100000 nM
Compound 4 gave a limit, no number; the forecaster's own chance of this, stated with the estimate: 85%; the middle value is on the limit's open side.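

Compound 4 gives > 100000 nM, which is a limit, so no step linking it to compound 1, compound 2 or compound 3 can be read: the limit of > 100000 nM in this assay, at which 4 of the 4 values shown sit.

The compounds shown leave open whether any exchange on that oxygen would give a measurable value in this assay.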